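Chloro for hydrogen on a pyrazoline-free aromatic ring: expected effect

The compounds below may be only part of what the source reports. "The series", "measured", "known", "first", "only" and "open" are said of these compounds alone.

Compound 1, `COc1ccc(C2=NN(C(N)=S)CC2C)cc1`: 40%
Compound 2, `CC1CN(C(N)=S)N=C1c1ccccc1`: "not active" (no number reported)

Two compounds sharing the same core were examined in an in vitro assay on cells for inhibition of Amine oxidase [flavin-containing] A (Homo sapiens), read by Amplex Red, with a stated time of 15 min, tested at 100 uM; a higher number here means more inhibition at the concentration tested (going by the name of the read-out), a lower number less inhibition. Compound 1, which carries a methoxy group on its phenyl ring, gives 40% in this assay. For the measured compounds named here, compound 2, which lacks any substituent on that ring, is recorded as "not active" (no number reported), with no number attached, so there is no single value on which compound 2 can be placed, and no measured step from compound 2 to another compound can be stated.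

Compound 3, `CC1CN(C(N)=S)N=C1c1ccc(Cl)cc1`, has not yet been measured. It differs from compound 2 by chloro in place of hydrogen on an aromatic carbon. Going by the values given here, with no measured step between substituted and unsubstituted partners of this core, the expectation rests only on compound 1, whose 40% shows that a group at the same place of the ring is compatible with a modest degree of inhibition. A modest rise in this assay relative to compound 2 is therefore expected, though it may stay within the scatter. Compound 3 is expected to give about 25%, within a range of 5% to 50%.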

Compound 3, a percentage reported as inhibition, at one concentration (the size of the read-out at that concentration, not a potency): 40%
Estimate against measurement, compound 3: 15 percentage points below; low and high end bracket the measured number.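

In this assay the exchange of methoxy for chloro on the aromatic carbon gives no change at the digits printed from compound 1 to compound 3 (within the scatter) and this shows that the reading at this place of the ring is not tied to methoxy alone. For the compounds shown here, compound 1 and compound 3 now give a number with two different groups on that carbon, while compound 2, with hydrogen there, is recorded without a number, so no step to or from compound 2 can be read, and the size of any gain from adding a group remains unknown. Nothing offered here accounts for the match between methoxy and chloro or for the record of compound 2.

The compounds shown leave open whether a quite different group on the same carbon, such as an amine, a carboxylic acid or a longer chain, would keep the reading at the level of compound 1 and compound 3. They also leave open whether chloro would give the same reading on another carbon of the ring, since every substituent shown here sits on the one carbon para to a group of 9 heavy atoms.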